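A Smaller Halogen on the Ring of Compound 2

A few compounds are considered here, and "the series" means these few. Any claim that something is new, unique, unknown or untested is made for them only; others in the source may bear on it.

Measured so far:
compound 1 `COc1ccc(OCC2=NCCO2)cc1`, giving 5%
compound 2 `Brc1ccccc1OCC1=NCCO1`, giving 10%
compound 3 `O=[N+]([O-])c1ccc(OCC2=NCCO2)cc1`, giving 10%

All three numbers come from a toxicity assay on the whole organism with Rattus norvegicus as the target, at a dose of 100 mg/kg by the oral route; a higher number here means a stronger effect of the compound at the dose given, a lower number a weaker effect. Compound 2 stands level with compound 3 at the digits shown, and together they are the highest of the three, while compound 1 lies a little lower; that gap to compound 1 is within the scatter, so no real order can be read among them. Among the compounds with values here, the one measured step, a number 5 percentage points higher from compound 1 to compound 3 (within the scatter), likewise stays within the scatter, which tells that swapping one group for another on the ring has so far left this read-out essentially flat.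

The unmeasured compound 4 `Fc1ccccc1OCC1=NCCO1` differs from compound 2 in one place: fluoro in place of bromo on an aromatic carbon. Within the data shown here, no measured step exchanges one halogen for another, so the only bearing comes from the general flatness seen from compound 1 to compound 3. On that basis no step beyond the scatter is expected in this assay for compound 4, and its estimated shift from compound 2 is a number 2 percentage points lower from compound 2 to compound 4 (within the scatter). Compound 4 is therefore expected to give about 8%, within a range from 0% to 25%.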

Compound 4, a percentage reported as activity, at one dose (the size of the read-out at that dose, not a potency): 10%
Estimate against measurement, compound 4: 2 percentage points below, and the stated range covers the measured number.
By their numbers in this assay, from the lowest: compounds 1, 2, 3 and 4 (each within the scatter of the next).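

In this assay, putting fluoro in place of bromo on this aromatic carbon, ortho to a group of 7 heavy atoms, gives no change at the digits printed from compound 2 to compound 4 (within the scatter). Within the data shown here, this is the first direct view of one halogen exchanged for another at this place, whereas the earlier step, a number 5 percentage points higher from compound 1 to compound 3 (within the scatter), concerned methoxy and nitro, so the flat picture now extends to a pair of halogens on the ring. Nothing available here explains why this exchange leaves the read-out flat, as no other measurement bears on the result.

The compounds shown leave open whether a group of a different kind on this aromatic carbon, such as an amine, a carboxylic acid or a longer chain, would move the read-out beyond the usual scatter, and whether a ring with only hydrogen at this place would read the same as compound 2 and compound 4. As far as these compounds go, each number also describes the size of the effect at a single dose, so how these compounds would compare at other doses remains open.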